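Restoring the amide methyl while moving the pyridine nitrogen

The compounds below may be only part of what the source reports. "The series", "measured", "known", "first", "only" and "open" are said of these compounds alone.

Measured compounds:
compound 1, `COc1ccc(-c2cccc(C(=O)N(C)Cc3ccccn3)c2)cc1S(=O)(=O)Nc1cccc(NCCNC(=O)c2cccc(C)c2)c1`, 235 nM
compound 2, `COc1ccc(-c2cccc(C(=O)NCc3ccccn3)c2)cc1S(=O)(=O)Nc1cccc(NCCNC(=O)c2cccc(C)c2)c1`, > 10000 nM

Compound 1 `COc1ccc(-c2cccc(C(=O)N(C)Cc3ccccn3)c2)cc1S(=O)(=O)Nc1cccc(NCCNC(=O)c2cccc(C)c2)c1` and compound 2 `COc1ccc(-c2cccc(C(=O)NCc3ccccn3)c2)cc1S(=O)(=O)Nc1cccc(NCCNC(=O)c2cccc(C)c2)c1` share the same core and differ only at the amide nitrogen. In a functional assay on CHO-RD-HGA16 cells for agonist activity at Orexin/Hypocretin receptor type 1 (Homo sapiens), read by fluorescence and calcium flux, with a stated time of 30 min (a higher number here means that more compound is needed for the effect, a lower number that less compound is needed), compound 1 gives 235 nM. For compound 2 the assay reports only a limit, > 10000 nM, and its value is therefore known only as lying at the limit (the limit of > 10000 nM in this assay, at which 1 of the 2 values shown sits). Among the measured compounds shown here, the step of an at least 42-fold higher number from compound 1 to compound 2 (1.62 log units; beyond the scatter) is the only measured change in this set.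

Compound 3 `COc1ccc(-c2cccc(C(=O)N(C)Cc3cccnc3)c2)cc1S(=O)(=O)Nc1cccc(NCCNC(=O)c2cccc(C)c2)c1` is not yet measured. It differs from compound 2 by methyl((pyridin-3-yl)methyl)amino in place of ((pyridin-2-yl)methyl)amino on a carbonyl carbon. Part of this change reverses what was measured from compound 1 to compound 2, since the methyl on the amide nitrogen returns; the shift of the ring nitrogen within the pyridine has no measured counterpart here. Given the size of an at least 42-fold higher number from compound 1 to compound 2 (1.62 log units; beyond the scatter), a large drop in the number is expected for compound 3, roughly an at least 20-fold lower number from compound 2 to compound 3 (1.30 log units; beyond the scatter), though the pyridine change leaves the exact size uncertain. Compound 3 is estimated at 500 nM, with a plausible range from 150 nM to 3000 nM.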

Compound 3, half-maximal effective concentration: 460 nM
Beside the measured number, compound 3's estimate is 1.1-fold (0.04 log units) above it; measured number inside the range.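

In this assay, moving from pyridin-2-yl to pyridin-3-yl on a saturated chain carbon bound to an amide-type nitrogen, with the amide methyl kept, gives a 2.0-fold higher number from compound 1 to compound 3 (0.29 log units; within the scatter), so the two pyridine forms cannot be told apart at this position. The earlier compounds shown here showed the effect of the amide methyl only with pyridin-2-yl, whereas the pyridin-3-yl compound with that methyl also gives a measurable number, and the change from the hydrogen-bearing pyridin-2-yl amide is an at least 21-fold lower number from compound 2 to compound 3 (1.33 log units; beyond the scatter). The value of compound 2 is a limit and not a number, so this step sets only a bound and its true size stays unknown: the limit of > 10000 nM in this assay, at which 1 of the 3 values shown sits.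

As far as these compounds go, the methyl and pyridine changes arrive together in that step, so what the amide hydrogen would do alongside pyridin-3-yl remains open. Also open, from the compounds shown here alone, is how far this tolerance extends, for instance to a pyridin-4-yl ring, a plain phenyl ring or an ethyl group on the amide nitrogen in this assay.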